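This account rests on a few compounds, and the source may have more. Where it says the series, first, only, none or still open, it means among the compounds named here.

Compound 1 has the structure `C=C1CC(COc2cc(C(=O)O)n(C)n2)(c2ccc(Cl)cc2)OC1=O`. In a functional assay on L1210 cells (Mus musculus) for antiproliferative activity (a lower number here means a stronger inhibitor, a higher number a weaker inhibitor), compound 1 gives > 10000 nM, which is a limit rather than a number. Compound 2, with the structure `C=C1CC(C)(COc2cc(C(=O)O)n(C)n2)OC1=O`, differs from compound 1 by a methyl in place of the 4-chlorophenyl on a saturated ring carbon. In this assay compound 2 gives > 10000 nM, again a limit and not a number. The step that the two limits leave unreadable from compound 1 to compound 2 therefore cannot be read, since both values sit at the limit of > 10000 nM in this assay, at which 2 of the 2 values shown sit. Compound 3, with the structure `C=C1CC(COc2cc(C(=O)O)n(C)n2)(c2ccc(-c3ccccc3)cc2)OC1=O`, keeps everything in compound 1 except the change (phenyl in place of chloro on an aromatic carbon), a phenyl in place of chloro on an aromatic carbon, para to a large group. Among the compounds with values here, no measured step touches that aromatic ring; the one recorded step, on a saturated ring carbon, tells only that neither of its compounds reached a number in this assay. With nothing readable to build on, the expected step is a step that the limit leaves unreadable from compound 1 to compound 3 in this assay. Compound 3 is thus estimated to give about 20000 nM in this assay, within a range from 4000 nM to 100000 nM, and a limit rather than a number is expected again.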

Compound 3, half-maximal inhibitory concentration: > 10000 nM
Compound 3: only a limit was reported (the forecaster's own chance of this, stated with the estimate: 80%); the middle value is on the limit's open side.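

In this assay the change from chloro to phenyl yields no readable step between compound 1 and compound 3, as each is recorded only as a limit rather than a number: the limit of > 10000 nM in this assay, at which 3 of the 3 values shown sit.

The compounds shown leave open how strongly any of them acts in this assay and whether changing this group alters that activity.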